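The source may report more compounds than this note shows. Statements on the series, on what has been measured and on what is new or still open speak of the compounds shown alone.

Measured in a functional assay on SW1573 cells (Homo sapiens) for inhibition, read by sulforhodamine B assay, with a stated time of 48 h; on this read-out lower numbers stand for stronger inhibition of growth and higher numbers for weaker inhibition of growth:

compound 1 `O=C(CCC(F)(F)C(F)(F)C(F)(F)C(F)(F)F)NCCCCCCCCCN[C@@H]1[C@H](O)[C@@H](O)[C@H](O)[C@H]2COC(=O)N21` gives > 100000 nM, a limit of this assay.
compound 2 `O=C(CCC(F)(F)C(F)(F)C(F)(F)C(F)(F)C(F)(F)C(F)(F)F)NCCCCCCCCCN[C@@H]1[C@H](O)[C@@H](O)[C@H](O)[C@H]2COC(=O)N21` gives 14000 nM.
compound 3 `O=C(CCC(F)(F)C(F)(F)C(F)(F)C(F)(F)F)NCCCCCCCCCN[C@@H]1[C@H](O)[C@@H](O)[C@@H](O)[C@H]2COC(=O)N21` gives > 100000 nM, a limit of this assay.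

Compound 1 and compound 2 differ by one change, (1,1,2,2,2-pentafluoroethyl in place of fluoro on a saturated chain carbon bound to two fluorine atoms and a saturated chain carbon), and it moves the read-out by an at least 7.1-fold lower number from compound 1 to compound 2 (0.85 log units; beyond the scatter). The size of that step is open at one end because the limit of > 100000 nM in this assay, at which 2 of the 3 values shown sit, holds for compound 1.

Compound 3 shares all atoms and bonds with compound 1; the cores differ only as the two compounds have the same atoms and bonds and differ only in configuration as drawn: 1 of 5 stereo elements differ; a stereocentre at a saturated ring carbon is drawn R in compound 1 and S in compound 3 describes. For the measured compounds named here, their step, a step that the two limits leave unreadable from compound 1 to compound 3, cannot be sized because the fact that compounds 1 and 3 differ only in the configuration as drawn meets two limits, and the pair shows only that both values sit at the limit of the assay.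

Compound 4 `O=C(CCC(F)(F)C(F)(F)C(F)(F)C(F)(F)C(F)(F)C(F)(F)F)NCCCCCCCCCN[C@@H]1[C@H](O)[C@@H](O)[C@@H](O)[C@H]2COC(=O)N21` is compound 3 carrying the same change, (1,1,2,2,2-pentafluoroethyl in place of fluoro on a saturated chain carbon bound to two fluorine atoms and a saturated chain carbon), with the place described in the same words as for compound 1 and compound 2, so it is the same change.

For compound 4 a step of an at least 5.0-fold lower number from compound 3 to compound 4 (0.69 log units; beyond the scatter) is expected, resting on the step of an at least 7.1-fold lower number from compound 1 to compound 2 (0.85 log units; beyond the scatter) measured for the same change in this assay; the open limits on both ends leave the size uncertain.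

Compound 4 is therefore estimated at 20000 nM in this assay, expected to lie between 6000 nM and 90000 nM.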

Compound 4, concentration for 50% growth inhibition: 14000 nM
For compound 4 the middle estimate is 1.4-fold (0.15 log units) above the measured one, within the range that was stated.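

Carrying the change onto the core of compound 3 gives an at least 7.1-fold lower number from compound 3 to compound 4 (0.85 log units; beyond the scatter) in this assay, so the direction seen on the core of compound 1 recurs on this second core: the same change on two cores in this assay, an at least 7.1-fold lower number (0.85 log units; beyond the scatter) from compound 1 to compound 2 and an at least 7.1-fold lower number (0.85 log units; beyond the scatter) from compound 3 to compound 4; the limit leaves it open whether they differ. With the 1,1,2,2,2-pentafluoroethyl change in place, the two drawn configurations at the saturated ring carbon give no change at the digits printed from compound 2 to compound 4 (within the scatter), so this pair offers no sign that the stereocentre matters to the read-out: the fact that compounds 2 and 4 differ only in the configuration as drawn. The full size of the change on either core stays unknown, and only two cores are shown, so this is no general rule for the series: the limit of > 100000 nM in this assay, at which 2 of the 4 values shown sit.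

On these data alone, it remains open whether a still longer perfluoroalkyl chain would carry the trend further, or whether it holds with a shorter chain linking the amide to the ring amine. As far as these compounds go, how a carboxylic acid or an amine at the fluorinated end of the chain would read in this assay also remains open.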